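Aryl substituent changes on the shared core: toward compound 4

The source may hold more compounds than are shown below. What is called first, only, known or untested is meant among the compounds shown, and "the series" means these compounds.

Compound 1 `O=C1C2=C(C(=O)c3ncccc31)C1(CS2)NC(=O)N(c2ccc(Cl)cc2)C1=O` sits second highest of the three measured analogues in a functional assay on CCRF-SB cells (Homo sapiens) for antiproliferative activity, read by MTT assay, with a stated time of 96 h; on this read-out higher numbers stand for weaker inhibition and lower numbers for stronger inhibition: compound 1 gives 10 nM, compound 2 `CCCc1ccc(N2C(=O)NC3(CSC4=C3C(=O)c3ncccc3C4=O)C2=O)cc1` gives 2 nM and compound 3 `CCCCCc1ccc(N2C(=O)NC3(CSC4=C3C(=O)c3ncccc3C4=O)C2=O)cc1` gives 150 nM. The change to compound 4 `CN(C)c1ccc(N2C(=O)NC3(CSC4=C3C(=O)c3ncccc3C4=O)C2=O)cc1` is dimethylamino in place of chloro on an aromatic carbon. The measured steps at the same aromatic carbon run in opposite directions: a 5.0-fold lower number from compound 1 to compound 2 (0.70 log units; beyond the scatter), whereas a 15-fold higher number from compound 1 to compound 3 (1.18 log units; beyond the scatter), and a 75-fold higher number from compound 2 to compound 3 (1.88 log units; beyond the scatter). None of them involves a dimethylamino group, so they bear on the new step only loosely; a step in either direction is possible, and only a modest one is expected. Compound 4 is estimated at 15 nM, with a range from 3 nM to 80 nM, meaning a 1.5-fold higher number from compound 1 to compound 4 (0.18 log units; within the scatter) is expected.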

Compound 4, half-maximal inhibitory concentration: 1 nM
Compound 4: the middle estimate sits 15-fold (1.18 log units) above what was measured; the measured number lies below the stated range.
By their numbers in this assay, from the lowest: compounds 4 and 2 (each within the scatter of the next); then compound 1; then compound 3.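

A dimethylamino group on this aromatic carbon, para to a large group, gives a clear gain over chloro (a 10-fold lower number from compound 1 to compound 4 (1.00 log units; beyond the scatter)), so a chain is not needed here for a low number. It stands far from the pentyl analogue (a 150-fold lower number from compound 3 to compound 4 (2.18 log units; beyond the scatter)) but cannot be told apart from the propyl analogue (a 2.0-fold lower number from compound 2 to compound 4 (0.30 log units; within the scatter)). No measurement shown explains these steps.

Open, on these data alone, is where a butyl chain falls between compound 2 and compound 3. Also open, as far as these compounds go, is whether a diethylamino group or a morpholine on this carbon stays near compound 4.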